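Swapping Trifluoromethyl for Methyl on an Aromatic Carbon

The source may hold more compounds than are shown below. What is called first, only, known or untested is meant among the compounds shown, and "the series" means these compounds.

Values in a functional assay on Bel-7402 cells (Homo sapiens) for inhibition, read by MTT assay, with a stated time of 24 h, tested at 10 ug/mL (a lower number here means less inhibition of growth, a higher number more inhibition of growth at the concentration tested), follow
- Compound 1 `O=C(CCCCC(S)CCS)Nc1ccccc1` gives 3.72%
- Compound 2 `O=C(CCCCC(S)CCS)Nc1cccc(Cl)c1` gives 3.22%
- Compound 3 `O=C(CCCCC(S)CCS)Nc1cccc(C(F)(F)F)c1` gives 1.21%

Compound 3 stands level with compound 1 and compound 2, since a number 2.5 percentage points lower from compound 1 to compound 3 (within the scatter) and a number 2 percentage points lower from compound 2 to compound 3 (within the scatter) both stay within the scatter. Compound 4 `Cc1cccc(NC(=O)CCCCC(S)CCS)c1` carries methyl in place of trifluoromethyl on an aromatic carbon. For the measured compounds named here, no measured step makes this exact swap. The closest evidence is a number 0.5 percentage points lower from compound 1 to compound 2 (within the scatter), with chloro in place of hydrogen, alongside the two steps above. All three are small, so no step beyond the scatter is expected in this assay. The expected change is a number 1.8 percentage points higher from compound 3 to compound 4 (within the scatter). For compound 4 the estimated value is 3%, with an expected range from 0% to 10%.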

Compound 4, percent growth inhibition at one concentration: 14.1%
Compound 4: the middle estimate sits 11.1 percentage points below what was measured; measured number above the stated range.
By their numbers in this assay, from the lowest: compounds 3, 2 and 1 (each within the scatter of the next); then compound 4.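

Methyl on this aromatic carbon is the first change to lift the number beyond the scatter in this assay, with a number 12.9 percentage points higher from compound 3 to compound 4 (beyond the scatter) and a number 10.9 percentage points higher from compound 2 to compound 4 (beyond the scatter) and a number 10.4 percentage points higher from compound 1 to compound 4 (beyond the scatter). So this position does respond to what sits on it, although hydrogen, chloro and trifluoromethyl stand level with one another. Nothing available explains why methyl stands apart. Still open, as far as these compounds go, is whether ethyl, methoxy or an amine at this position would give a similar number, or a different one.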